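This account rests on a few compounds, and the source may have more. Where it says the series, first, only, none or still open, it means among the compounds named here.

Measured in a functional assay on A549 cells (Homo sapiens) for inhibition, read by MTT assay, with a stated time of 48 h; a lower number here means a stronger inhibitor, a higher number a weaker inhibitor:
- compound 1 `COc1cc(-c2nccn3cc(-c4ccccc4)nc23)cc(OC)c1OC`: 378 nM
- compound 2 `COc1cc(-c2nccn3cc(-c4ccc(C(F)(F)F)cc4)nc23)cc(OC)c1OC`: > 10000 nM (a limit, not a number)

The entry for compound 2 is a limit of this assay, so this compound has no exact value. Among the measured compounds shown here, its single measured step came from placing trifluoromethyl where compound 1 has hydrogen on an aromatic carbon, and that step is an at least 26-fold higher number from compound 1 to compound 2 (1.42 log units; beyond the scatter).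

Compound 3 `COc1cc(-c2nccn3cc(-c4ccc(N)cc4)nc23)cc(OC)c1OC` has not yet been measured. It keeps the shared core but carries amino in place of trifluoromethyl, on an aromatic carbon of a six-membered aromatic ring of carbon only, para to a large group: amino in place of trifluoromethyl on an aromatic carbon.

Only the large step above bears on this change, since it concerns the same place. Compound 3 loses the trifluoromethyl of that step, so a large move to a lower number is expected, back towards compound 1 at 378 nM. For the measured compounds named here, no measured compound carries amino, which leaves the size uncertain, and the range is wide.

The expected step is an at least 11-fold lower number from compound 2 to compound 3 (1.04 log units; beyond the scatter).

For compound 3, the estimated value is 900 nM, with an expected range of 120 nM to 7000 nM.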

Compound 3, half-maximal inhibitory concentration: 287 nM
Estimate against measurement, compound 3: 3.1-fold (0.50 log units) above; the range from low to high includes it.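

At the aromatic carbon para to a large group, the loss seen with trifluoromethyl does not extend to every substituent in this assay: amino in place of trifluoromethyl restores a strong result (an at least 34-fold lower number from compound 2 to compound 3 (1.54 log units; beyond the scatter)). Amino in place of hydrogen on the same carbon makes no difference that can be told from ordinary scatter (a 1.3-fold lower number from compound 1 to compound 3 (0.12 log units; within the scatter)), so this position accepts at least one group other than hydrogen without a measurable penalty. The step involving compound 2 gives only a minimum size, as the entry for compound 2 is a limit and not a number: the limit of > 10000 nM in this assay, at which 1 of the 3 values shown sits.

The compounds shown do not settle whether the weak result belongs to trifluoromethyl alone or also appears with other groups on this carbon, such as methyl, chlorine or a carboxylic acid. Whether a substituted amine such as dimethylamino, or an amide built on the amino nitrogen, would stay level with compound 3 also remains open, as does the reason for the weak result with trifluoromethyl.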